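Removing the Urea Cap from Compound 1

This account rests on a few compounds, and the source may have more. Where it says the series, first, only, none or still open, it means among the compounds named here.

Compound 1 `C[C@@H]1CN(c2ccc(-c3n[nH]c4cnc(N5[C@H](C)CN(C(=O)N(C)C)C[C@@H]5C)nc34)cn2)CCN1` is the stronger of the two compounds measured in an assay on Sf9 cells for inhibition of activin receptor type-1 (Homo sapiens), read by HTRF, with a stated time of 3 h, in the presence of a further agent that is not named here; a lower number here means a stronger inhibitor, a higher number a weaker inhibitor: compound 1 gives 6.4 nM, whereas compound 2 `C[C@@H]1CN(c2ccc(-c3n[nH]c4ccc(N5CCCCC5)nc34)cn2)CCN1` gives 95 nM, a gap beyond the scatter. Compound 3 `C[C@@H]1CN(c2ccc(-c3n[nH]c4cnc(N5[C@H](C)CNC[C@@H]5C)nc34)cn2)CCN1` differs from compound 1 by hydrogen in place of dimethylcarbamoyl on an amine nitrogen in a ring. Among the compounds with values here, no measured pair isolates this change, so the expectation rests on compound 1 alone. For compound 3 a modest shift toward a higher number is expected, a 2.3-fold higher number from compound 1 to compound 3 (0.37 log units; beyond the scatter), perhaps not beyond the scatter. Compound 3 is therefore estimated at 15 nM, within a range of 4 nM to 60 nM.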

Compound 3, half-maximal inhibitory concentration: 793 nM
Compound 3: the middle estimate sits 53-fold (1.72 log units) below what was measured, and the stated range ends below it.
By their numbers in this assay, from the lowest: compound 1; then compound 2; then compound 3.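

In this assay the ring amine nitrogen proves far from indifferent to what it bears: hydrogen in place of dimethylcarbamoyl gives a 120-fold higher number from compound 1 to compound 3 (2.09 log units; beyond the scatter) and so costs most of the strength of compound 1. Within the data shown here, no earlier pair isolated this change, so this is the first direct reading of the position. Nothing available accounts for the size of the step. The compounds shown leave open whether the whole urea is needed, or whether a smaller acyl group such as acetyl, or a simple methyl on the same nitrogen, would hold the strength.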